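Adding a methoxy to the ether chain of compound 1

The source may hold more compounds than are shown below. What is called first, only, known or untested is meant among the compounds shown, and "the series" means these compounds.

Measured compounds:
- compound 1, `COc1ccc(C2=C(c3cc(OC)c(OC)c(OC)c3)C(=O)CC2O[SiH2]C(C)(C)C)cc1OC`: > 100 ug/mL
- compound 2, `COc1ccc(C2=C(c3cc(OC)c(OC)c(OC)c3)CC(O[SiH2]C(C)(C)C)C2=O)cc1[N+](=O)[O-]`: > 100 ug/mL
- compound 3, `COc1ccc(C2=C(c3cc(OC)c(OC)c(OC)c3)C(=O)C(OC(C)=O)C2)cc1Cl`: 64 ug/mL

All three were tested in an ADME assay on KB cells (Homo sapiens) for cytotoxicity, read by MTT assay, with a stated time of 72 h; on this read-out lower numbers stand for stronger inhibition and higher numbers for weaker inhibition. Compound 1 gives > 100 ug/mL, which is a limit of the assay rather than a number. Compound 2 also reaches only a limit, > 100 ug/mL. Compound 3 gives a measured number, 64 ug/mL. So compound 1 sits at the limit, as described by the limit of > 100 ug/mL in this assay, at which 2 of the 3 values shown sit, and no step between two measured compounds is available to calibrate any change.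

The unmeasured compound 4, `COCOc1cc(C2=C(c3cc(OC)c(OC)c(OC)c3)C(=O)CC2O[SiH2]C(C)(C)C)ccc1OC`, differs from compound 1 by methoxy in place of hydrogen on a saturated chain carbon bound to an oxygen on an aromatic ring. The change sits on the outer edge of the molecule, away from the shared core.

Among the compounds with values here, since compound 1 gives only a limit, > 100 ug/mL, in this assay, there is no number from which a direction could be read, and no other pair offers a comparable change. The expectation is therefore a step that the limit leaves unreadable from compound 1 to compound 4 from compound 1 to compound 4, that is, nothing beyond the scatter. Compound 4 is estimated at 120 ug/mL, with a range from 50 ug/mL to 300 ug/mL, and most likely the assay again reports only a limit.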

Compound 4, half-maximal inhibitory concentration: 33 ug/mL
Beside the measured number, compound 4's estimate is 3.6-fold (0.56 log units) above it; the measured number lies below the stated range.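

In this assay, methoxy in place of hydrogen on a saturated chain carbon bound to an oxygen on an aromatic ring gives an at least 3.0-fold lower number from compound 1 to compound 4 (0.48 log units; beyond the scatter). Within the data shown here, this shows that the outer edge of the molecule is not a silent place: going from 3,4-dimethoxyphenyl to 4-methoxy-3-(methoxymethoxy)phenyl on the shared core is enough to bring a compound off the limit and give a real number, something the earlier compounds could not show, since they offered no one-place step. The step gives only a lower bound on the size of the change, because its starting point is a limit rather than a number: the limit of > 100 ug/mL in this assay, at which 2 of the 4 values shown sit.

The compounds shown leave open whether the oxygen of the new methoxymethoxy group matters or the added length alone, which a plain propoxy chain in the same place would help to separate. They also leave open whether an amine or a carboxylic acid at the end of this chain would move the number further, and whether the same change would act in the same direction on a core carrying a different set of groups.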